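This account rests on a few compounds, and the source may have more. Where it says the series, first, only, none or still open, it means among the compounds named here.

In a functional assay on HL-60 cells (Homo sapiens) for antiproliferative activity, read by MTT assay, with a stated time of 48 h (on this read-out lower numbers stand for stronger inhibition and higher numbers for weaker inhibition), three compounds sharing one core have been measured. Compound 1 `CC(C)=CCC[C@]1(C)/C=C/[C@@H](OC(=O)C=C(C)C)[C@](C)(O)/C=C/C(=O)/C(CCl)=C\C1`, with chloro on a saturated chain carbon bound to a double-bonded ring carbon, gives 160 nM. Compound 2 `CC(C)=CCC[C@]1(C)/C=C/[C@@H](OC(=O)C=C(C)C)[C@](C)(O)/C=C/C(=O)/C(CN(C(C)C)C(C)C)=C\C1`, with diisopropylamino at that place, gives 740 nM. Compound 3 `CC(C)=CCC[C@]1(C)/C=C/[C@@H](OC(=O)C=C(C)C)[C@](C)(O)/C=C/C(=O)/C(CN2CCCC2)=C\C1`, with pyrrolidin-1-yl there, gives 160 nM, level with compound 1 and sharing the lowest number of the three.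

Compound 4 `CC(C)=CCC[C@]1(C)/C=C/[C@@H](OC(=O)C=C(C)C)[C@](C)(O)/C=C/C(=O)/C(COC(=O)c2ccc([N+](=O)[O-])cc2)=C\C1` changes only this substituent: ((4-nitrophenyl)carbonyl)oxy in place of pyrrolidin-1-yl on a saturated chain carbon bound to a double-bonded ring carbon. Within the data shown here, no measured compound carries a ((4-nitrophenyl)carbonyl)oxy group, so the data offer no direct guide. The nearest evidence is the three swaps at the same carbon, which show no change at the digits printed from compound 1 to compound 3 (within the scatter), a 4.6-fold higher number from compound 1 to compound 2 (0.67 log units; beyond the scatter) and a 4.6-fold lower number from compound 2 to compound 3 (0.67 log units; beyond the scatter). Those steps range from none beyond the scatter to modest, so a modest step toward a higher number is expected in this assay, though its direction is uncertain. The expected change is a 2.2-fold higher number from compound 3 to compound 4 (0.34 log units; beyond the scatter). Compound 4 is estimated at 350 nM, with an expected range of 110 nM to 1100 nM.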

Compound 4, half-maximal inhibitory concentration: 830 nM
Compound 4: middle estimate off by 2.4-fold (0.38 log units), on the low side, within the range that was stated.
By their numbers in this assay, from the lowest: compounds 1 and 3 (each within the scatter of the next); then compounds 2 and 4 (each within the scatter of the next).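

In this assay, the ((4-nitrophenyl)carbonyl)oxy group, the first at this carbon attached through oxygen, gives a 5.2-fold higher number from compound 3 to compound 4 (0.71 log units; beyond the scatter) and a 5.2-fold higher number from compound 1 to compound 4 (0.71 log units; beyond the scatter), yet only a 1.1-fold higher number from compound 2 to compound 4 (0.05 log units; within the scatter). The saturated chain carbon therefore accepts this group of 12 heavy atoms, but compound 4 falls with compound 2 at the higher level rather than with compounds 1 and 3. The presence of an amino group does not sort these levels, as pyrrolidin-1-yl sits with chloro while diisopropylamino sits with the group lacking such an amine.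

An acetyloxy or unsubstituted benzoyloxy group at this carbon could show whether the ester link or the 4-nitrophenyl ring goes with the higher number. No available evidence explains why the four groups divide this way.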